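Heptyl to isopropyl on the shared core

The source may hold more compounds than are shown below. What is called first, only, known or untested is meant among the compounds shown, and "the series" means these compounds.

In a functional assay on PC-3 cells (Homo sapiens) for antiproliferative activity, read by WST assay, with a stated time of 3 days (a higher number here means a weaker inhibitor, a lower number a stronger inhibitor), compound 1 `CCOc1c(-c2cc(OC)c(OC)c(OC)c2)oc2ccccc2c1=O` gives 900 nM as its read-out. Compound 2 `CCCCCCCOc1c(-c2cc(OC)c(OC)c(OC)c2)oc2ccccc2c1=O` stands at > 50000 nM and this is a limit of the assay, not a number. Within the data shown here, the one measured step that bears on the next change is an at least 55-fold higher number from compound 1 to compound 2 (1.74 log units; beyond the scatter) and it is large. Compound 3 `COc1cc(-c2oc3ccccc3c(=O)c2OC(C)C)cc(OC)c1OC` carries isopropyl in place of heptyl on an oxygen on an aromatic ring. With heptyl gone, compound 3 is expected to read near compound 1 at 900 nM. In this assay a large fall in the number is expected (an at least 33-fold lower number from compound 2 to compound 3 (1.52 log units; beyond the scatter)). The estimated value for compound 3 is 1500 nM (expected range 400 nM to 6000 nM).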

Compound 3, half-maximal inhibitory concentration: 21200 nM
Compound 3: middle estimate off by 14-fold (1.15 log units), on the low side; the measured number lies above the stated range.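

In this assay, isopropyl in place of heptyl on the oxygen gives an at least 2.3-fold lower number from compound 2 to compound 3 (0.37 log units; beyond the scatter), so the shorter branched group does not return the read-out to that of compound 1. One methyl in place of hydrogen on the saturated chain carbon bound to the oxygen gives a 24-fold higher number from compound 1 to compound 3 (1.37 log units; beyond the scatter), which shows that this position responds strongly to a small change, not only to a long chain. Compound 2 is read only as a limit of the assay: the limit of > 50000 nM in this assay, at which 1 of the 3 values shown sits.

Going by these compounds, how an unbranched propyl chain or a free hydroxyl on this oxygen would read remains open. The compounds shown therefore do not separate branching from chain length.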